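Removing one chloro from a dichloro growth inhibitor

This account rests on a few compounds, and the source may have more. Where it says the series, first, only, none or still open, it means among the compounds named here.

Measured compounds:
- compound 1 `O=c1c(C2N=C(c3ccccc3)SS2)coc2ccc(Cl)cc12`: 71%
- compound 2 `O=c1c(C2N=C(c3ccccc3)SS2)coc2cc(Cl)c(Cl)cc12`: 68%
- compound 3 `O=c1c(C(=S)Nc2ccccc2)coc2cc(Cl)c(Cl)cc12`: 2%

In a functional assay on OVCAR-3 cells (Homo sapiens) for inhibition, read by sulforhodamine B assay, with a stated time of 48 h, tested at 100 uM (a higher number here means more inhibition of growth at the concentration tested, a lower number less inhibition of growth), compound 2 stands second highest of the three numbers. Among the measured compounds shown here, its nearest neighbour is compound 1, whose value is higher by an amount within the scatter; compound 3 lies far below it, beyond the scatter, and that pair has no single-change step between them, so only the gap in their values can be noted.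

Compound 4 `O=c1c(C2N=C(c3ccccc3)SS2)coc2cc(Cl)ccc12` is not yet measured. It differs from compound 2 by hydrogen in place of chloro on an aromatic carbon. For the measured compounds named here, the one step that bears on this is the step from compound 1 to compound 2, a number 3 percentage points lower from compound 1 to compound 2 (within the scatter), which is the same kind of change in the opposite direction, chloro entering where hydrogen stood. Since that step stayed within the scatter, taking a chloro away again is expected to move the number little or not at all in this assay.

Compound 4 is therefore expected to give 68%, with a range from 55% to 81%, which is an estimated step of no change at the digits printed from compound 2 to compound 4 (within the scatter).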

Compound 4, percent growth inhibition at one concentration: 91%
Estimate against measurement, compound 4: 23 percentage points below; measured number outside the range, above it.
By their numbers in this assay, from the lowest: compound 3; then compounds 2 and 1 (each within the scatter of the next); then compound 4.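

Replacing this chloro, which sits ortho to a chloro group, with hydrogen gives a number 23 percentage points higher from compound 2 to compound 4 (beyond the scatter) in this assay. The earlier step, a number 3 percentage points lower from compound 1 to compound 2 (within the scatter), involved the other chloro of the pair, so the same kind of change on two different aromatic carbons does not give the same outcome, and which chloro is absent matters in this small set. No measurement offered here accounts for this difference between the two carbons.

The compounds shown carry only chloro or hydrogen on this carbon, so what an amine, a methoxy group or a carboxylic acid would do there in this assay stays open. Also open, on these data alone, is whether the same swap of chloro for hydrogen would give a similar step on the core of compound 3.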